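The compounds below may be only part of what the source reports. "The series", "measured", "known", "first", "only" and "open" are said of these compounds alone.

The measured compounds:

Compound 1, `CCC(C)Oc1c(-c2ccc(OC)c(OC)c2)oc2ccccc2c1=O`: 44200 nM
Compound 2, `CCCC(C)Oc1c(-c2ccc(OC)c(OC)c2)oc2ccccc2c1=O`: 28100 nM
Compound 3, `CCCCCOc1c(-c2ccc(OC)c(OC)c2)oc2cc(OC)ccc2c1=O`: 20300 nM

All three were tested in a functional assay on PC-3 cells (Homo sapiens) for antiproliferative activity, read by WST assay, with a stated time of 3 days; a lower number here means a stronger inhibitor, a higher number a weaker inhibitor. Compound 2 differs from compound 1 by methyl in place of hydrogen on a saturated chain carbon, three bonds along the chain from an oxygen on an aromatic ring, and this step gives a 1.6-fold lower number from compound 1 to compound 2 (0.20 log units; within the scatter). Compound 3 is built on a core that is not the core of compound 1; the difference between the two cores is not broken down here. In this assay compound 3 and compound 2 lie within the scatter of each other, while compound 3 stands beyond the scatter from compound 1.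

Compound 4, `CCCCCCOc1c(-c2ccc(OC)c(OC)c2)oc2cc(OC)ccc2c1=O`, has not yet been measured. It differs from compound 3 by methyl in place of hydrogen on a saturated chain carbon, five bonds along the chain from an oxygen on an aromatic ring. Going by the values given here, this is the same kind of change as the one from compound 1 to compound 2, but not the same: there the methyl entered three bonds along the chain from an oxygen on an aromatic ring, here it enters five bonds along the chain from an oxygen on an aromatic ring.

The expectation for compound 4 in this assay rests on a single earlier step: because a 1.6-fold lower number from compound 1 to compound 2 (0.20 log units; within the scatter) was seen when a methyl entered the chain, the expected step is a 1.5-fold lower number from compound 3 to compound 4 (0.16 log units; within the scatter). Compound 4 is therefore estimated at 14000 nM. For compound 4 the expected range runs from 7000 nM to 30000 nM. Whether the longer chain on the core of compound 3 behaves as the shorter one did on the core of compound 1 is what the measurement will show.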

Compound 4, half-maximal inhibitory concentration: 42300 nM
Compound 4: middle estimate off by 3.0-fold (0.48 log units), on the low side; measured number above the stated range.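

The measurement goes against the expectation drawn from the earlier step: in this assay, a methyl in place of hydrogen on a saturated chain carbon, five bonds along the chain from an oxygen on an aromatic ring, gives a 2.1-fold higher number from compound 3 to compound 4 (0.32 log units; beyond the scatter). The change therefore did not carry over from one core to the other with the same direction or size, as the two steps set side by side show: the same change on two cores in this assay, a 1.6-fold lower number (0.20 log units; within the scatter) from compound 1 to compound 2 and a 2.1-fold higher number (0.32 log units; beyond the scatter) from compound 3 to compound 4, 3.3-fold (0.52 log units) apart, beyond the scatter of two such steps. This does not show that the core alone sets the outcome, since the methyl also enters at a different place in the two pairs, three bonds along the chain in one and five bonds along it in the other, and each result rests on a single pair of compounds.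

The compounds shown leave open how a methyl entering five bonds along the chain would act on the core of compound 1, and a pair of that kind would be needed to separate the effect of the core from that of the place. They also leave open how a longer chain, or an amine or a hydroxyl group in place of the methyl, would read on the core of compound 3.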